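Adding 4-methylphenyl to the ring nitrogen of compound 2

The compounds below may be only part of what the source reports. "The series", "measured", "known", "first", "only" and "open" are said of these compounds alone.

Measured so far in a functional assay on HeLa cells (Homo sapiens) for antiproliferative activity, read by MTT assay, with a stated time of 72 h (a lower number here means a stronger inhibitor, a higher number a weaker inhibitor), are two compounds:
Compound 1 `COc1ccc(N2C(=O)COc3ccc(-c4cnc(Cl)c(NS(=O)(=O)c5ccc(F)cc5)c4)cc32)cc1` gives 8320 nM
Compound 2 `O=C1COc2ccc(-c3cnc(Cl)c(NS(=O)(=O)c4ccc(F)cc4)c3)cc2N1` gives 15600 nM

With only these two numbers, compound 2 has a single measured neighbour. Among the compounds with values here, the one measured step is a 1.9-fold higher number from compound 1 to compound 2 (0.27 log units; within the scatter) and so the two compounds cannot be told apart.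

Compound 3 `Cc1ccc(N2C(=O)COc3ccc(-c4cnc(Cl)c(NS(=O)(=O)c5ccc(F)cc5)c4)cc32)cc1` keeps the core of compound 2 and differs in one place, counted by 4-methylphenyl in place of hydrogen on an amide-type nitrogen in a ring in full: 4-methylphenyl in place of hydrogen on an amide-type nitrogen in a ring.

The closest evidence is compound 1, which carries 4-methoxyphenyl on that same nitrogen. With compound 1 at 8320 nM in this assay and its step to compound 2 inside the scatter, only a small step toward a lower number is expected for the new group, and nothing beyond the scatter. A single step is thin evidence, so the range stays wide. The estimated step is a 1.8-fold lower number from compound 2 to compound 3 (0.26 log units; within the scatter) and no larger one is expected. For compound 3 the expected value is 8500 nM with an estimated range of 3500 nM to 20000 nM in this same read-out.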

Compound 3, half-maximal inhibitory concentration: 32300 nM
Compound 3: the middle estimate sits 3.8-fold (0.58 log units) below what was measured, and the stated range ends below it.
By their numbers in this assay, from the lowest: compounds 1 and 2 (each within the scatter of the next); then compound 3.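

In this assay, placing a ring on this amide-type nitrogen does not have one fixed outcome: 4-methylphenyl gives a 2.1-fold higher number from compound 2 to compound 3 (0.32 log units; beyond the scatter), whereas 4-methoxyphenyl on the same nitrogen gives only a 1.9-fold higher number from compound 1 to compound 2 (0.27 log units; within the scatter). The clearest new information comes from the swap within the added ring, methyl in place of methoxy on an aromatic carbon, which gives a 3.9-fold higher number from compound 1 to compound 3 (0.59 log units; beyond the scatter), so the group on that ring matters here and not just the presence of the ring, and compound 3 is the weakest inhibitor of the three. Both new steps are modest, and nothing available explains why methyl and methoxy differ in this way.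

These three compounds cannot show whether the trend seen with methoxy and methyl would extend to other groups at the same place on the added ring, such as chlorine, an amine or a carboxylic acid. They also leave open how this nitrogen would respond to a group without an aromatic ring, such as a plain methyl or a longer carbon chain, and whether any such change could bring a step well beyond the scatter toward a lower number.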